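Thiazolyl ketone pyrimidinone series: aryl swap on the core

The source may report more compounds than this note shows. Statements on the series, on what has been measured and on what is new or still open speak of the compounds shown alone.

Measured so far:
compound 1, `COc1ccc(-c2nc(C)c(C(=O)CSc3nc(-c4ccc(OC)cc4)c(C#N)c(=O)[nH]3)s2)cc1`, 32.6%
compound 2, `Cc1nc(-c2ccc(Cl)cc2)sc1C(=O)CSc1nc(-c2ccc(Cl)c(Cl)c2)c(C#N)c(=O)[nH]1`, 93.9%
compound 3, `Cc1nc(-c2ccccc2)sc1C(=O)CSc1nc(-c2ccc(Cl)c(Cl)c2)c(C#N)c(=O)[nH]1`, 75.3%

In a functional assay on U-87MG ATCC cells for antiproliferative activity against U-87 MG (Homo sapiens), read by MTT assay, with a stated time of 48 h, tested at 50 uM (a higher number here means a weaker effect of the compound at the concentration tested, a lower number a stronger effect), compound 2 gives 93.9%, the highest of the three numbers; its nearest neighbour is compound 3, and the furthest is compound 1 with 32.6%.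

Going by the values given here, the one step measured between single-change neighbours is a number 18.6 percentage points lower from compound 2 to compound 3 (beyond the scatter), a hydrogen in place of chloro on an aromatic carbon. It sits on the other aryl group of the shared core and so bears only indirectly on the present change.

Compound 4, `COc1ccc(-c2nc(SCC(=O)c3sc(-c4ccc(Cl)cc4)nc3C)[nH]c(=O)c2C#N)cc1`, differs from compound 2 by 4-methoxyphenyl in place of 3,4-dichlorophenyl on an aromatic carbon. Among the compounds with values here, no measured pair isolates this change. Compound 1, which carries the same 4-methoxyphenyl at this place but differs from compound 4 elsewhere, gives the lowest number, so a substantial drop from compound 2 is expected, though not necessarily to the level of compound 1.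

Compound 4 is therefore estimated at 55%, with a range of 30% to 85%. The expected step is a number 38.9 percentage points lower from compound 2 to compound 4 (beyond the scatter), beyond the scatter and downward.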

Compound 4, a percentage reported as activity, at one concentration (the size of the read-out at that concentration, not a potency): 46.3%
Compound 4: middle estimate off by 8.7 percentage points, on the high side; the range from low to high includes it.
By their numbers in this assay, from the lowest: compound 1; then compound 4; then compound 3; then compound 2.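

In this assay the aryl swap on the core, on the aromatic carbon next to the ring nitrogen and ortho to a cyano group, now has a measured size: a number 47.6 percentage points lower from compound 2 to compound 4 (beyond the scatter), a large step, whereas the steps on the other aryl group are modest. Compound 4 also gives a second pair on that other aryl group, a number 13.7 percentage points higher from compound 1 to compound 4 (beyond the scatter), so most of the distance between compound 2 and compound 1 is already present in compound 4, where the 4-methoxyphenyl sits on the core and the chloro is retained. In both pairs read on that group, chloro goes with the higher number, the other pair being a number 18.6 percentage points lower from compound 2 to compound 3 (beyond the scatter), and neither goes against this, although two pairs are a thin basis.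

Nothing available gives a reason for either step. Still open, going by these compounds, is how an amine or a carboxylic acid on the aryl group at this place would read, and whether an unsubstituted phenyl there would sit nearer to compound 2 or to compound 4.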